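This account rests on a few compounds, and the source may have more. Where it says the series, first, only, none or still open, it means among the compounds named here.

In a functional assay on MT4 cells (Homo sapiens), read by MTT assay (on this read-out higher numbers stand for lower toxicity in this test and lower numbers for higher toxicity in this test), three related compounds have been read so far. Compound 1 (`C#C[C@]1(CO)OC(N2C=C(C)C(O)NC2=O)[C@@H](O)[C@@H]1O`) gives > 350000 nM as its reading, and this is a limit of the assay rather than a number. Compound 2 (`C#C[C@]1(CO)OC(N2C=CC(N)NC2=O)[C@@H](O)[C@@H]1O`) gives 1740 nM as a true number, the only one available, and it marks this compound as the most clearly toxic reading of the set. Compound 3 (`C#C[C@]1(CO)O[C@@H](n2cc(C)c(=O)[nH]c2=O)C[C@@H]1O`) gives > 380000 nM as its reading, which is also a limit. So compound 3 stands at the low-toxicity end of the scale, where the assay stops giving numbers.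

Compound 4 (`C#C[C@]1(CO)O[C@@H](n2ccc(=O)[nH]c2=O)C[C@@H]1O`) differs from compound 3 in one place, with hydrogen in place of methyl on an aromatic carbon. Within the data shown here, no measured pair shows this change alone, so the expectation rests on how small it is. No step beyond the usual scatter is expected in this assay for this swap. The expected step is an at least 1.0-fold lower number from compound 3 to compound 4 (0.03 log units; that floor lies within the scatter) and it may be hidden behind a limit. For compound 4 the estimated value is 350000 nM with an expected range of 100000 nM to 420000 nM in this test.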

Compound 4, half-maximal cytotoxic concentration: > 100000 nM
Compound 4: a limit, no number (the forecaster's own chance of this, stated with the estimate: 70%); the middle value does not contradict the limit.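

In this assay compound 4 gives > 100000 nM, a limit and not a number. Among these compounds, compound 3 also stands at a limit, so no step between compound 3 and compound 4 can be read. The compounds shown leave open whether hydrogen in place of methyl on an aromatic carbon changes the reading in this assay at all.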